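Taking the chloro group off compound 3

The compounds below may be only part of what the source reports. "The series", "measured", "known", "first", "only" and "open" are said of these compounds alone.

Values in a functional assay on SW480 cells (Homo sapiens) for antiproliferative activity, read by MTT assay, with a stated time of 48 h; on this read-out higher numbers stand for weaker inhibition and lower numbers for stronger inhibition:
Compound 1 `CC(CCO)n1cnc2c(Cl)ncnc21`: > 50000 nM
Compound 2 `CCCCCCC(CCO)n1cnc2c(Cl)nc(F)nc21`: 12900 nM
Compound 3 `CCCCCCC(CCO)n1cnc2c(Cl)ncnc21`: 16700 nM

The entry for compound 1 is a limit, not a number. Compound 3, at 16700 nM, sits level with compound 2, as a 1.3-fold higher number from compound 2 to compound 3 (0.11 log units; within the scatter) shows. The pentyl group separates it from the limit of compound 1: an at least 2.9-fold lower number from compound 1 to compound 3 (0.47 log units; beyond the scatter).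

Compound 4 `CCCCCCC(CCO)n1cnc2cncnc21` has hydrogen in place of chloro on an aromatic carbon. Among the compounds with values here, no measured compound lacks the chloro group, so no step bears on this change directly. The closest parallel is the loss of fluoro on another aromatic carbon, a 1.3-fold higher number from compound 2 to compound 3 (0.11 log units; within the scatter), which suggests that a small step is possible. However, that parallel is weak, and a modest move towards a higher number in this assay is expected, with the limit of the assay within reach. Compound 4 is estimated at 30000 nM, with an expected range of 13000 nM to 60000 nM. The expected step is a 1.8-fold higher number from compound 3 to compound 4 (0.25 log units; within the scatter).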

Compound 4, half-maximal inhibitory concentration: > 50000 nM
Compound 4 gave a limit, no number; the forecaster's own chance of this, stated with the estimate: 35%; at least 1.6-fold (0.22 log units) between middle value and limit.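

Replacing chloro with hydrogen on this aromatic carbon gave a change beyond the scatter in this assay, an at least 2.9-fold higher number from compound 3 to compound 4 (0.47 log units; beyond the scatter), whereas the loss of fluoro on another aromatic carbon stayed within it, a 1.3-fold higher number from compound 2 to compound 3 (0.11 log units; within the scatter). The pentyl group that set compound 3 apart from compound 1 is still present in compound 4, so in these compounds that chain does not bring a measurable number without the chloro group. How large the step truly is cannot be read, since it ends on a limit: the limit of > 50000 nM in this assay, at which 2 of the 4 values shown sit.

From the compounds shown here alone, whether bromo, an amine or a methoxy group on this carbon would keep the activity of compound 3, or improve on it, remains open. So does whether a longer chain in place of the pentyl group would lower the number further.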